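The compounds below may be only part of what the source reports. "The series", "measured", "known", "first", "only" and "open" are said of these compounds alone.

In a functional assay on MDA-MB-231 cells (Homo sapiens) for antiproliferative activity, read by MTT assay, with a stated time of 24 h (a higher number here means a weaker inhibitor, a lower number a stronger inhibitor), compound 1 `COC(=O)c1scc(-c2ccc(NC(=O)c3ccc4ccccc4c3)cc2)c1OC` gives 5250 nM and compound 2 `COC(=O)c1scc(-c2ccc(NC(=O)c3ccc(F)c(Cl)n3)cc2)c1OC` gives 10300 nM. Going by the values given here, compound 2 therefore has the higher of only two numbers, but the gap between them lies within the usual scatter, so the two cannot be ranked. Compound 3 `COC(=O)c1scc(-c2ccc(NC(=O)c3cc(I)ccc3F)cc2)c1OC` keeps the shared core and the amide and alters only the group on the carbonyl carbon: 2-fluoro-5-iodophenyl in place of 6-chloro-5-fluoropyridin-2-yl on a carbonyl carbon. In words, 2-fluoro-5-iodophenyl takes the place of 6-chloro-5-fluoropyridin-2-yl. Among the compounds with values here, one measured step bears on this change, since it altered the same place: a 2.0-fold higher number from compound 1 to compound 2 (0.29 log units; within the scatter), with 6-chloro-5-fluoropyridin-2-yl replacing naphthalen-2-yl. Within the data shown here, that step is small, and it is the only evidence, as no measured compound yet carries the 2-fluoro-5-iodophenyl group. A step beyond the scatter is therefore not expected in this assay, and neither direction is firmly favoured. The expected change is a 1.4-fold lower number from compound 2 to compound 3 (0.14 log units; within the scatter). For compound 3, the estimated value is 7500 nM, with an expected range from 3000 nM to 18000 nM.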

Compound 3, half-maximal inhibitory concentration: 16500 nM
The estimate for compound 3 lay 2.2-fold (0.34 log units) below the measured number; the measured number falls inside the stated range.
By their numbers in this assay, from the lowest: compounds 1, 2 and 3 (each within the scatter of the next, the first and the last beyond it).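

In this assay the step of a 1.6-fold higher number from compound 2 to compound 3 (0.20 log units; within the scatter) leaves the 2-fluoro-5-iodophenyl and 6-chloro-5-fluoropyridin-2-yl groups unranked, even though the two groups have the same number of heavy atoms and differ in ring type and halogens. Going by these compounds alone, the comparison with the naphthalen-2-yl group reads differently: a 3.1-fold higher number from compound 1 to compound 3 (0.50 log units; beyond the scatter) is the first step at this position to lie beyond the scatter, so the group on the carbonyl carbon can make a modest difference, with compound 3 the weaker inhibitor of that pair. No measurement shown here offers an explanation for that gap.

The three groups shown at this position are all aromatic, so it remains open whether a cyclohexyl ring, a longer alkyl chain, or a group carrying an amine or a carboxylic acid would give a lower number than the naphthalen-2-yl group. An unsubstituted phenyl group, set against compound 3, would also help to show whether the fluorine and iodine atoms on that ring matter at all.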